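The compounds below may be only part of what the source reports. "The series", "measured", "known", "first", "only" and "open" are said of these compounds alone.

Compound 1 `FC(F)(F)c1ccc(/C=C\c2cc3ccccc3nc2Cl)cc1`: in a functional assay on MDA-MB-468 cells (Homo sapiens) for antiproliferative activity, read by sulforhodamine B assay, with a stated time of 72 h (on this read-out lower numbers stand for stronger inhibition and higher numbers for weaker inhibition), compound 1 gives 7380 nM.
Compound 2 `Fc1ccc(/C=C\c2cc3ccccc3nc2Cl)cc1`: in this assay compound 2 gives 5290 nM.
Compound 3 `FC(F)(F)c1ccc(/C=C\c2cc3ccc(Cl)cc3nc2Cl)cc1`: in this assay compound 3 gives 16100 nM.

These three compounds share a stilbene-like arrangement in which a chlorinated quinoline is linked to a benzene ring, and they differ only at two points. Among the compounds with values here, the first point is the group on the benzene ring. Going from compound 1 to compound 2, the change is fluoro in place of trifluoromethyl on an aromatic carbon, and the step was a 1.4-fold lower number from compound 1 to compound 2 (0.14 log units; within the scatter). The second point is the core itself: compound 3 differs from compound 1 by chloro in place of hydrogen on an aromatic carbon, and the step was a 2.2-fold higher number from compound 1 to compound 3 (0.34 log units; beyond the scatter), so compound 3 stands at the highest number of the three.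

Compound 4 `Fc1ccc(/C=C\c2cc3ccc(Cl)cc3nc2Cl)cc1` has not been measured. Within the data shown here, it differs from compound 3 by fluoro in place of trifluoromethyl on an aromatic carbon, which is the same change as the one from compound 1 to compound 2, made here on the core of compound 3. The place of the change is the same in both pairs. Because that earlier step was a 1.4-fold lower number from compound 1 to compound 2 (0.14 log units; within the scatter), the expectation for compound 4 in this assay is a step of about a 1.4-fold lower number from compound 3 to compound 4 (0.15 log units; within the scatter), starting from the value of compound 3. The expected number for compound 4 is therefore 11500 nM, most likely between 5500 nM and 24000 nM, which rests on a single earlier example of this change and so is uncertain.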

Compound 4, half-maximal inhibitory concentration: 10900 nM
Compound 4: middle estimate off by 1.1-fold (0.02 log units), on the high side, and the stated range covers the measured number.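

In this assay, putting fluoro in place of trifluoromethyl on the core that carries the added chloro gave a 1.5-fold lower number from compound 3 to compound 4 (0.17 log units; within the scatter), and this matches the same change on the core of compound 1: the same change on two cores in this assay, a 1.4-fold lower number (0.14 log units; within the scatter) from compound 1 to compound 2 and a 1.5-fold lower number (0.17 log units; within the scatter) from compound 3 to compound 4, 1.1-fold (0.02 log units) apart, within the scatter of two such steps. Adding the chloro also carried over, with the fluoro-bearing pair giving a 2.1-fold higher number from compound 2 to compound 4 (0.31 log units; beyond the scatter), which matches the step seen in the trifluoromethyl-bearing pair: the same change on two cores in this assay, a 2.2-fold higher number (0.34 log units; beyond the scatter) from compound 1 to compound 3 and a 2.1-fold higher number (0.31 log units; beyond the scatter) from compound 2 to compound 4, 1.1-fold (0.02 log units) apart, within the scatter of two such steps. Across these four compounds, each change therefore behaves the same whichever form the other point takes, but this rests on only two examples of each change, the fluoro step lies within the scatter on both cores, and nothing here shows that the agreement would hold on any other core or explains why it occurs.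

The compounds shown leave open what an amine, a methoxy group or a carboxylic acid would do in place of trifluoromethyl or fluoro on that aromatic carbon. They also leave open whether a group other than chloro, such as a methyl or a nitrile, would give a step of similar size when added to the core at the same place.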